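Ethyl ester analogue of a benzamide acid: cytotoxicity outlook

A few compounds are considered here, and "the series" means these few. Any claim that something is new, unique, unknown or untested is made for them only; others in the source may bear on it.

Compound 1 `CC(C)N(Cc1cccc(OCCCCCC(=O)O)c1)C(=O)c1ccccc1`: in an ADME assay on BJ cells (Homo sapiens) for cytotoxicity, read by CellTiter-Glo and resazurin assay, with a stated time of 72 h (a higher number here means that more compound is needed for the effect, a lower number that less compound is needed), compound 1 gives > 26000 nM, which is a limit of the assay.
Compound 2 `CCOc1cccc(-c2ccc(C(=O)N(Cc3cccc(OCCCCCC(=O)O)c3)C(C)C)cc2)c1`: compound 2 gives > 20800 nM, also a limit.
Compound 3 `CC(C)N(Cc1cccc(OCCCCCC(=O)O)c1)C(=O)c1ccc(-c2cccc(O)c2)cc1`: compound 3 gives > 26000 nM, likewise a limit.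

Since all three values are limits, the step that the two limits leave unreadable from compound 3 to compound 2 has no readable size; the change behind it is ethyl in place of hydrogen on an oxygen on an aromatic ring. Compound 4 `CCOC(=O)CCCCCOc1cccc(CN(C(=O)c2ccccc2)C(C)C)c1` carries a change of the same kind on compound 1, (ethyl in place of hydrogen on an oxygen next to a carbonyl group), although the place differs: on an oxygen on an aromatic ring in the measured pair, on an oxygen next to a carbonyl group here. The two cores differ by hydrogen in place of 3-hydroxyphenyl on an aromatic carbon. Because compound 1 sits at the limit of > 26000 nM in this assay, at which 2 of the 3 values shown sit, and the measured step of this kind is unreadable, compound 4 is expected to show a number no higher from compound 1 to compound 4 (the limit leaves the size open) and most likely another limit. Compound 4 is thus estimated at 26000 nM, expected between 12000 nM and 60000 nM.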

Compound 4, half-maximal effective concentration: > 26000 nM
Compound 4: a limit, no number; the forecaster's own chance of this, stated with the estimate: 85%; the middle value sits exactly at the limit.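

No step can be read between compound 1 and compound 4: each gives only a limit, not a number. The compounds shown leave open what concentration of any of them reaches the half-maximal effect, and whether the ethyl group shifts it.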